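The source may report more compounds than this note shows. Statements on the series, on what has been measured and on what is new or still open speak of the compounds shown alone.

Compound 1, `O=c1c2cnn(-c3ccc(F)cc3)c2ncn1CC1(O)CCN(Cc2ccc(Cl)cc2)CC1`, and compound 2, `O=c1c2cnn(-c3ccc(F)cc3)c2ncn1CC1(O)CCN(Cc2ccc(Br)cc2)CC1`, share one core and differ in a single place: bromo in place of chloro on an aromatic carbon. In an assay on Sf21 cells for inhibition of ubiquitin carboxyl-terminal hydrolase 7 (Homo sapiens), read by spectrophotometry, with stated times of 30 min and 2 h (on this read-out lower numbers stand for stronger inhibition and higher numbers for weaker inhibition), compound 1 gives 8000 nM, and in this assay compound 2 gives 6700 nM. The step between them is a 1.2-fold lower number from compound 1 to compound 2 (0.08 log units; within the scatter), so the two values cannot be told apart.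

Compound 3, `COC(=O)c1ccc(CN2CCC(O)(Cn3cnc4c(cnn4-c4ccc(F)cc4)c3=O)CC2)c(Cl)c1`, carries a different benzyl group on the same core; the difference from compound 1 is 2-chloro-4-(methoxycarbonyl)phenyl in place of 4-chlorophenyl on a saturated chain carbon bound to an amine nitrogen in a ring. In this assay compound 3 gives 800 nM. That is a 10-fold lower number from compound 1 to compound 3 (1.00 log units; beyond the scatter) and an 8.4-fold lower number from compound 2 to compound 3 (0.92 log units; beyond the scatter), so compound 3 stands lowest of the three measured numbers, with both of its steps beyond the scatter.

Compound 4, `COC(=O)c1ccc(CN2CCC(O)(Cn3cnc4c(cnn4-c4ccc(F)cc4)c3=O)CC2)c(Br)c1`, has not been measured. It differs from compound 3 by bromo in place of chloro on an aromatic carbon. This is the same kind of change as that from compound 1 to compound 2, but not the same: there the place was para to a large group, whereas here the bromo sits ortho to a large group and meta to a methoxycarbonyl group. For the measured compounds named here, the one measured instance of this halogen swap gave a 1.2-fold lower number from compound 1 to compound 2 (0.08 log units; within the scatter), and nothing among the measured compounds suggests the position on the ring will alter that. Compound 4 is therefore expected to sit close to compound 3, with an estimated step of a 1.1-fold lower number from compound 3 to compound 4 (0.03 log units; within the scatter) in this assay. For compound 4 the estimate in this assay is 750 nM, with a likely range from 350 nM to 1600 nM.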

Compound 4, half-maximal inhibitory concentration: 900 nM
The estimate for compound 4 lay 1.2-fold (0.08 log units) below the measured number, within the range that was stated.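

In this assay, bromo in place of chloro on the 2-chloro-4-(methoxycarbonyl)benzyl group gives a 1.1-fold higher number from compound 3 to compound 4 (0.05 log units; within the scatter), and this step does not differ from the one seen earlier on the simpler benzyl group: the same change on two cores in this assay, a 1.2-fold lower number (0.08 log units; within the scatter) from compound 1 to compound 2 and a 1.1-fold higher number (0.05 log units; within the scatter) from compound 3 to compound 4, 1.3-fold (0.13 log units) apart, within the scatter of two such steps The benzyl change also holds with bromo in the new group, with 2-bromo-4-(methoxycarbonyl)phenyl giving a 7.4-fold lower number from compound 2 to compound 4 (0.87 log units; beyond the scatter) when it replaces 4-bromophenyl and an 8.9-fold lower number from compound 1 to compound 4 (0.95 log units; beyond the scatter) when it replaces 4-chlorophenyl, so the halogen swap leaves compound 4 apart from compound 1 and compound 2, as compound 3 is. This shows that, on these two cores, the swap of chloro for bromo carries over with no change that can be told from the scatter, but it rests on a single pair for each core, with the halogen at a different place in each, and it does not show that the same would hold on other cores or for other halogens.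

The compounds shown leave open how much of the lower numbers belongs to the methoxycarbonyl group and how much to the halogen at its place on the ring, since the two always appear together here. Also open, on these data alone, is how a carboxylic acid or a primary amide in place of the methoxycarbonyl group, or fluoro or methyl in place of the halogen, would read in this assay.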